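A few compounds are considered here, and "the series" means these few. Any claim that something is new, unique, unknown or untested is made for them only; others in the source may bear on it.

Working notes on the series. Compound 1 `COc1cccc(CNC(=O)c2cccc(C(C)Oc3ccnc(Nc4cnn(C)c4)c3)c2)c1` is measured in a functional assay on NCI-H3122 cells (Homo sapiens) for antiproliferative activity, read by MTT assay, with a stated time of 48 h; a lower number here means a stronger inhibitor, a higher number a weaker inhibitor. In this assay compound 1 gives only a limit, > 100000 nM, and no number. Compound 2 `CC(Oc1ccnc(Nc2cnn(C3CCN(C)CC3)c2)c1)c1cccc(C(=O)NCc2ccc(Cl)c(C(F)(F)F)c2)c1` shares the core of compound 1 but differs at more than one place; in this assay compound 2 gives 8000 nM. Among the measured compounds shown here, no single-change step between measured compounds exists, so where compound 1 stands can be said only this far: it sits at the limit of > 100000 nM in this assay, at which 1 of the 2 values shown sits, while compound 2 gives a number. Compound 3 `CC(Oc1ccnc(Nc2cnn(C)c2)c1)c1cccc(C(=O)NCc2ccc(C#N)cc2)c1` is the next compound to be measured in this assay. It differs from compound 1 in one place: 4-cyanophenyl in place of 3-methoxyphenyl on a saturated chain carbon bound to an amide-type nitrogen. For the measured compounds named here, no measured step reports what this exchange does. The expectation is a step of an at least 2.0-fold lower number from compound 1 to compound 3 (0.30 log units; that floor lies within the scatter) toward a stronger inhibitor, though compound 1 offers only its limit > 100000 nM as a starting point, and a step within the scatter cannot be ruled out. Compound 3 is therefore estimated at 50000 nM, with a range from 8000 nM to 100000 nM, and a real chance that only a limit is returned.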

Compound 3, half-maximal inhibitory concentration: 35100 nM
Compound 3: middle estimate off by 1.4-fold (0.15 log units), on the high side; low and high end bracket the measured number.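

In this assay, among the compounds shown here, 4-cyanophenyl in place of 3-methoxyphenyl on a saturated chain carbon bound to an amide-type nitrogen gives an at least 2.8-fold lower number from compound 1 to compound 3 (0.45 log units; beyond the scatter), the only readable single-change step so far. This shows that the read-out responds to this position: with the rest of compound 1 held fixed, the exchange alone turns a limit into a number. Compound 3 gives 35100 nM. The step has a floor but no known upper size, and the true difference may be larger, because the value of compound 1 is a limit and not a number: the limit of > 100000 nM in this assay, at which 1 of the 3 values shown sits.

The exchange changes both the group on the ring and where it sits, so 4-methoxyphenyl or 3-cyanophenyl at this place would be needed to tell which of the two carries the step. Also open, on these data alone, is whether a carboxylic acid or an aminomethyl group in place of the nitrile would move the number further in either direction, and whether the step holds on a compound that differs elsewhere from compound 1.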